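Swapping Ethyl for Trifluoromethyl on the Shared Core

This account rests on a few compounds, and the source may have more. Where it says the series, first, only, none or still open, it means among the compounds named here.

- Compound 1 `CN(C)[C@H]1CC[C@H](Nc2ncnc3[nH]ccc23)CC1`: -0.6
- Compound 2 `CCc1c[nH]c2ncnc(N[C@H]3CC[C@H](N(C)C)CC3)c12`: 0.6

In a physicochemical assay for lipophilicity, using the shake flask method, at pH 7.4 (on this read-out lower numbers stand for lower lipophilicity and higher numbers for higher lipophilicity), compound 2 is the higher of the two measured compounds at 0.6. The next structure, compound 3 `CN(C)[C@H]1CC[C@H](Nc2ncnc3[nH]cc(C(F)(F)F)c23)CC1`, departs from it in one place: trifluoromethyl in place of ethyl on an aromatic carbon. This is trifluoromethyl in place of ethyl on an aromatic carbon.

Among the measured compounds shown here, only one measured step bears on this change. Ethyl in place of hydrogen on an aromatic carbon gave a number 1.20 log units higher from compound 1 to compound 2 (beyond the scatter), a large step. For the measured compounds named here, no measured step involves trifluoromethyl, so this evidence is indirect and the uncertainty is wide. Compound 3 keeps a group at the place where compound 1 has hydrogen, so no return toward compound 1 at -0.6 is expected. One group replacing another is expected to move this assay far less than the step from hydrogen did, with no clear direction and nothing beyond the scatter. The estimated change is a number 0.10 log units lower from compound 2 to compound 3 (within the scatter). For compound 3 the expected value is 0.5, with an estimated range from 0 to 1.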

Compound 3, distribution coefficient: 1.5
For compound 3 the middle estimate is 1.00 log units below the measured one, outside the stated range (above it).
By their numbers in this assay, from the lowest: compound 1; then compound 2; then compound 3.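

At this aromatic carbon of the five-membered aromatic ring, this assay responds to which group is present and not only to whether hydrogen has been replaced: trifluoromethyl in place of ethyl gave a number 0.90 log units higher from compound 2 to compound 3 (beyond the scatter). Set against hydrogen, trifluoromethyl gave a number 2.10 log units higher from compound 1 to compound 3 (beyond the scatter), so the span at this one carbon is wider than the ethyl step had shown. Among the compounds shown here, both groups move the number the same way from hydrogen, and the three compounds now rank hydrogen, then ethyl, then trifluoromethyl, with no compound among them going against that order. No measurement in hand accounts for the gap between ethyl and trifluoromethyl at this carbon.

Three compounds cannot show where other groups at this carbon would fall in that order, whether a methyl group, a chlorine atom, a nitrile or a longer chain such as propyl. They also leave open whether the trifluoromethyl step would keep its size if the shared core carried a different amine elsewhere.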